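This account rests on a few compounds, and the source may have more. Where it says the series, first, only, none or still open, it means among the compounds named here.

Compound 3 `CC(C)(C)CNc1nc(NCC2CC2)cc(-c2ccccn2)n1` is one of three compounds tested in a functional assay on HEK293 cells for agonist activity at G-protein coupled receptor 39 (Mus musculus), read by inositol phosphate accumulation (a higher number here means that more compound is needed for the effect, a lower number that less compound is needed), where compound 3 gives 1500 nM. That places it second highest of the three numbers. Its nearest neighbour is compound 1 `c1ccc(-c2cc(NCC3CC3)ncn2)nc1`, which in this assay gives 10000 nM; the furthest is compound 2 `CNc1nc(NCc2ccc(Cl)cc2Cl)cc(-c2ccccn2)n1`, which in this assay gives 0.5 nM. Compound 1 and compound 3 differ in one place, neopentylamino in place of hydrogen on an aromatic carbon, and that change gives a 6.7-fold lower number from compound 1 to compound 3 (0.82 log units; beyond the scatter).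

Compound 4 `CNc1nc(NCC2CC2)cc(-c2ccccn2)n1` keeps the whole framework of compound 3 but carries hydrogen in place of tert-butyl on a saturated chain carbon bound to a nitrogen on an aromatic ring; said one bond further out, neopentylamino becomes methylamino. Within the data shown here, no measured pair shows this exact change. Among the measured compounds shown here, the one step in hand shows that the amino substituent at that position matters, since removing it entirely gives a 6.7-fold lower number from compound 1 to compound 3 (0.82 log units; beyond the scatter) in reverse. Compound 2 also carries a methylamino group, and in this assay compound 2 gives 0.5 nM, but it differs from compound 4 elsewhere as well, so its number cannot be read as a direct guide. The expectation is therefore that compound 4 keeps an amino group and stays within reach of compound 3, with a step of a 2.5-fold lower number from compound 3 to compound 4 (0.40 log units; beyond the scatter) expected. For compound 4 the estimate is 600 nM, with a range from 150 nM to 2500 nM.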

Compound 4, half-maximal effective concentration: 115 nM
Estimate against measurement, compound 4: 5.2-fold (0.72 log units) above; measured number below the stated range.
By their numbers in this assay, from the lowest: compound 2; then compound 4; then compound 3; then compound 1.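

Taking the tert-butyl off the chain and leaving hydrogen, so that neopentylamino becomes methylamino, gives a 13-fold lower number from compound 3 to compound 4 (1.12 log units; beyond the scatter) in this assay, which shows that the number responds strongly to what sits on this amino group and not merely to whether an amino group is present. Compound 1 has no amino group at this position, and adding methylamino to it gives an 87-fold lower number from compound 1 to compound 4 (1.94 log units; beyond the scatter), a larger step than the one neopentylamino gives, a 6.7-fold lower number from compound 1 to compound 3 (0.82 log units; beyond the scatter). With methylamino held constant, the other amine arm still has the greater reach: cyclopropyl in place of 2,4-dichlorophenyl on a saturated chain carbon bound to a nitrogen on an aromatic ring gives a 230-fold higher number from compound 2 to compound 4 (2.36 log units; beyond the scatter).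

Nothing available explains why any of these steps has the size it has. Still open, as far as these compounds go, is how the number behaves for groups of intermediate size, such as ethylamino or isopropylamino, whether a plain unsubstituted amino group would continue the trend from neopentylamino to methylamino, and whether the same order would hold with 2,4-dichlorophenyl on the other arm.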